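Removing One Chloro Group from the Shared Core

A few compounds are considered here, and "the series" means these few. Any claim that something is new, unique, unknown or untested is made for them only; others in the source may bear on it.

Of the compounds shown here, three have so far been measured in a functional assay on SF-295 cells (Homo sapiens) for cytotoxicity, read by sulforhodamine B assay, with a stated time of 48 h; on this read-out lower numbers stand for stronger inhibition of growth and higher numbers for weaker inhibition of growth. Compound 1 `ClCc1cccc(Cn2cnc3c(Cl)nc(Cl)nc32)c1` gives 4360 nM, the lowest of the three numbers. Compound 3 `ClCc1ccc(Cn2cnc3c(Cl)nc(Cl)nc32)cc1` gives 7240 nM, and compound 2 `Nc1nc(Cl)c2ncn(Cc3ccccc3CCl)c2n1` gives 7410 nM. Both of these values lie within the usual scatter of the value of compound 1, so the three compounds cannot be ordered against one another on these data, and none of them can be called the most or least active.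

The account now turns to compound 4 `ClCc1cccc(Cn2cnc3c(Cl)ncnc32)c1`, which has not yet been measured in this assay. It differs from compound 1 in a single place: hydrogen in place of chloro on an aromatic carbon.

Going by the values given here, no pair of measured compounds differs in only one place, so no measured step gives a direct reading of what this change does. The three measured values all fall close together, and nothing among them points to a large shift in either direction. A step from compound 1 to compound 4 of a 1.4-fold higher number from compound 1 to compound 4 (0.14 log units; within the scatter) is expected, toward a somewhat higher number, but one that may well stay within the scatter. Compound 4 is therefore estimated at 6000 nM, with a range from 2500 nM to 15000 nM.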

Compound 4, concentration for 50% growth inhibition: 3230 nM
Beside the measured number, compound 4's estimate is 1.9-fold (0.27 log units) above it, and the stated range covers the measured number.
By their numbers in this assay, from the lowest: compounds 4, 1, 3 and 2 (each within the scatter of the next, the first and the last beyond it).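

Going by these compounds alone, the step of a 1.3-fold lower number from compound 1 to compound 4 (0.13 log units; within the scatter) in this assay is the first direct reading of this position, since no earlier pair of measured compounds differed in only one place. It shows that, on this read-out, compound 1 and compound 4 cannot be told apart when the chloro group on the aromatic carbon between two ring nitrogen atoms gives way to hydrogen, so the activity of compound 1 does not depend measurably on that chloro group. No measured information on the compounds accounts for this result.

The compounds shown leave open whether a methoxy group, a methyl group or a longer chain on this same carbon would also leave the number within the scatter, as this one exchange speaks only for hydrogen in place of chloro. They also leave open what the same exchange would do to the remaining chloro group on this ring, which stays in place in both compound 1 and compound 4.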